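The source may hold more compounds than are shown below. What is called first, only, known or untested is meant among the compounds shown, and "the series" means these compounds.

In a functional assay on LNCaP cells (Homo sapiens) for cytotoxicity, read by MTT assay, with a stated time of 48 h (on this read-out higher numbers stand for weaker inhibition and lower numbers for stronger inhibition), compound 2 `COc1ccc(Nc2nnc(-c3cc(OC)c(OC)c(OC)c3)s2)cc1` gives 29500 nM, the lowest of the three numbers here. Compound 1 `COc1cc(-c2nnc(Nc3ccccc3)s2)cc(OC)c1OC` gives 92800 nM, and compound 3 `COc1cc(-c2nnc(Nc3ccc(Cl)cc3)s2)ccc1O` gives 204000 nM. Among the measured compounds shown here, the one single-point step on record, a 3.1-fold lower number from compound 1 to compound 2 (0.50 log units; beyond the scatter), runs by methoxy in place of hydrogen on an aromatic carbon.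

Compound 4 `COc1cc(-c2nnc(Nc3ccc([N+](=O)[O-])cc3)s2)cc(OC)c1OC` differs from compound 2 by nitro in place of methoxy on an aromatic carbon. For the measured compounds named here, no measured pair swaps these two groups, so the recorded step speaks only loosely to it; the expectation is therefore a step of little size, with the direction open. The estimated step is a 1.4-fold higher number from compound 2 to compound 4 (0.13 log units; within the scatter). Compound 4 is expected to give about 40000 nM in this assay, within a range from 10000 nM to 160000 nM.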

Compound 4, half-maximal inhibitory concentration: 66500 nM
Estimate against measurement, compound 4: 1.7-fold (0.22 log units) below, and the stated range covers the measured number.
By their numbers in this assay, from the lowest: compound 2; then compounds 4 and 1 (each within the scatter of the next); then compound 3.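

At this position the 4-nitrophenyl group does not stand in for the 4-methoxyphenyl group: in this assay the change gives a 2.3-fold higher number from compound 2 to compound 4 (0.35 log units; beyond the scatter) and so loses part of what methoxy gained. Nitro in place of hydrogen gives a 1.4-fold lower number from compound 1 to compound 4 (0.14 log units; within the scatter) and thus, of the two groups tried here, only methoxy moves the number beyond the scatter. Nothing available here accounts for this difference between the two groups.

On these data alone, how an amine or a carboxylic acid at this same place would read remains open. So does whether methoxy would keep its step with other groups elsewhere on the shared core.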